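The source may report more compounds than this note shows. Statements on the series, on what has been measured and on what is new or still open speak of the compounds shown alone.

Compound 1 `CCOc1nc(-c2cc3ccccc3o2)cc(-c2ccccc2)c1C#N` is a weak inhibitor in a functional assay on aorta (strain Wistar) for inhibition, with Thoracic aorta (Rattus norvegicus) as the target (a lower number here means a stronger inhibitor, a higher number a weaker inhibitor), where compound 1 gives 310000 nM. The three numbers measured here all lie within the usual scatter of one another: compound 3 `COc1nc(-c2cc3ccccc3o2)cc(-c2ccc(F)cc2)c1C#N` gives 321000 nM and is the nearest to compound 1, while compound 2 `CCOc1nc(-c2cc3ccccc3o2)cc(-c2ccc(Cl)cc2)c1C#N` gives 221000 nM, the step of a 1.4-fold lower number from compound 1 to compound 2 (0.15 log units; within the scatter) being the widest gap. Compound 4 `CCOc1nc(-c2cc3ccccc3o2)cc(-c2ccc(F)cc2)c1C#N` carries fluoro in place of hydrogen on an aromatic carbon compared with compound 1. Among the measured compounds shown here, the only measured step that bears on this change is a 1.4-fold lower number from compound 1 to compound 2 (0.15 log units; within the scatter), a different halogen at the same place, and it stayed within the scatter. Compound 3 has fluoro at that place but also a different alkoxy group, so no single step is shown for it. The expected step of a 1.1-fold lower number from compound 1 to compound 4 (0.03 log units; within the scatter) is therefore none beyond the scatter, and compound 4 is estimated at 290000 nM with a range from 150000 nM to 560000 nM.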

Compound 4, half-maximal inhibitory concentration: 396000 nM
For compound 4 the middle estimate is 1.4-fold (0.14 log units) below the measured one, and the stated range covers the measured number.
By their numbers in this assay, from the lowest: compounds 2, 1, 3 and 4 (each within the scatter of the next).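

Among the compounds shown here, replacing phenyl with 4-fluorophenyl gives the first direct fluoro step at this position in this assay (a 1.3-fold higher number from compound 1 to compound 4 (0.11 log units; within the scatter)), and it lies within the scatter, as the chloro step did. Exchanging the halogen (a 1.8-fold higher number from compound 2 to compound 4 (0.25 log units; within the scatter)) and adding a methyl to the alkoxy chain (a 1.2-fold higher number from compound 3 to compound 4 (0.09 log units; within the scatter)) also stay within the scatter, so neither change separates these compounds. No measured evidence accounts for these small steps.

From the compounds shown here alone, whether an amine or a carboxylic acid at this position, or a longer chain on the oxygen, would shift the number beyond the scatter remains open.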